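Thieno-fused aminopyrimidines: aryl to pyridyl at the ring carbon

The source may report more compounds than this note shows. Statements on the series, on what has been measured and on what is new or still open speak of the compounds shown alone.

Measured so far in a functional assay on CHO-K1 cells for antagonist activity at adenosine receptor A1 (Homo sapiens), read by a beta-galactosidase reporter and cAMP accumulation, with stated times of 15 min and 6 h; on this read-out lower numbers stand for stronger inhibition and higher numbers for weaker inhibition:
compound 1 `Nc1nc(C2CCCO2)nc2sc(Cc3ccccc3)cc12` gives 2950 nM
compound 2 `Nc1nc(-c2cccc(F)c2)nc2sc(Cc3ccccc3)cc12` gives 123 nM

Compound 2 holds the lowest of the two numbers in this assay; its nearest neighbour is compound 1, and the step of a 24-fold lower number from compound 1 to compound 2 (1.38 log units; beyond the scatter) is the only one recorded. Compound 3 `Nc1nc(-c2cccnc2)nc2sc(Cc3ccccc3)cc12` differs from compound 2 by pyridin-3-yl in place of 3-fluorophenyl on an aromatic carbon. For the measured compounds named here, no measured step covers an exchange of this kind; the recorded step concerns a different group. Little change is therefore expected, and compound 3 is estimated at 220 nM (range 60 nM to 800 nM), a step of a 1.8-fold higher number from compound 2 to compound 3 (0.25 log units; within the scatter) that is expected to stay near the scatter.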

Compound 3, inhibition constant: 1420 nM
Compound 3: middle estimate off by 6.5-fold (0.81 log units), on the low side, outside the stated range (above it).
By their numbers in this assay, from the lowest: compound 2; then compound 3; then compound 1.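

Pyridin-3-yl does not stand in for 3-fluorophenyl at this ring carbon in this assay: the exchange gives a 12-fold higher number from compound 2 to compound 3 (1.06 log units; beyond the scatter) and removes most of the advantage of the aryl group over oxolan-2-yl. What remains against the saturated ring is small, with a 2.1-fold lower number from compound 1 to compound 3 (0.32 log units; beyond the scatter) for this pair. Nothing measured accounts for the loss.

The compounds shown leave open whether the loss follows the ring nitrogen or the absent fluorine, which a plain phenyl would separate. Pyridin-2-yl and pyridin-4-yl would test whether the place of that nitrogen matters.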